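The source may hold more compounds than are shown below. What is called first, only, known or untested is meant among the compounds shown, and "the series" means these compounds.

Working notes on the series, measured in an ADME assay on MDBK cells (Bos taurus) for cytotoxicity; on this read-out higher numbers stand for lower toxicity in this test and lower numbers for higher toxicity in this test:

- compound 1 `c1ccc(Cn2ccc3nc(-c4ccccc4)nc-3c2)cc1`: > 100000 nM, a limit
- compound 2 `Clc1cccc(Cn2ccc3nc(-c4ccccc4)nc-3c2)c1`: > 100000 nM, a limit
- compound 3 `CCn1ccc2nc(-c3ccccc3)nc-2c1`: > 100000 nM, a limit

Compound 3 has no numerical value, only this limit, and the same holds for the other two compounds. The evidence so far is the limit of > 100000 nM in this assay, at which 3 of the 3 values shown sit.

The next compound is compound 4 `c1ccc(-c2nc3ccn(Cc4cccnc4)cc-3n2)cc1`, still unmeasured. The change is pyridin-3-yl in place of methyl on a saturated chain carbon bound to an aromatic nitrogen.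

The closest comparison is compound 1, which has phenyl in that place, and a step that the two limits leave unreadable from compound 1 to compound 3 gives no size. The same holds for compound 2, with 3-chlorophenyl in that place, where a step that the two limits leave unreadable from compound 2 to compound 3 is equally without a size. a step that the two limits leave unreadable from compound 1 to compound 2 adds nothing further. Neither an aromatic ring on this carbon nor its removal has yet produced a number in this assay, so no direction can be drawn from these steps. No shift beyond the usual scatter is expected, and a further limit is the likely report.

The expected outcome is a number no higher from compound 3 to compound 4 (the limit leaves the size open), estimated as no real change. For compound 4 the estimated value is 100000 nM, with an expected range of 40000 nM to 200000 nM.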

Compound 4, half-maximal cytotoxic concentration: > 100000 nM
Compound 4: a limit, no number; the forecaster's own chance of this, stated with the estimate: 85%; the middle value lies on the limit itself.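

No step can be read from compound 4 to compound 1, compound 2 or compound 3 in this assay, as all four compounds report only a limit: the limit of > 100000 nM in this assay, at which 4 of the 4 values shown sit.

The compounds shown leave open whether any group on the saturated chain carbon bound to an aromatic nitrogen gives a numerical value on this read-out, and how large any difference between them would be.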